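Isopropyl in Place of Pentyl on the Shared Core

This account rests on a few compounds, and the source may have more. Where it says the series, first, only, none or still open, it means among the compounds named here.

Measured compounds:
compound 1 `CCCCCc1ccc(Nc2ccc3c(c2)C(=O)N(C2CCC(=O)NC2=O)C3=O)cc1` — 12%
compound 2 `Cc1ccccc1Nc1cccc2c1C(=O)N(C1CCC(=O)NC1=O)C2=O` — 7%
compound 3 `CCCCCc1ccc(Nc2cccc3c2C(=O)N(C2CCC(=O)NC2=O)C3=O)cc1` — 23%

Of the compounds shown here, three on one shared core have been measured in an assay on FRT-Jurkat cells for inhibition of nuclear factor NF-kappa-B complex (Homo sapiens), read by flow cytometry, with a stated time of 24 h, tested at 10 uM (a higher number here means more inhibition at the concentration tested (going by the name of the read-out), a lower number less inhibition), where compound 1 gives 12%. This is the second highest of the three numbers. The nearest is compound 2, whose value lies a little lower but within the usual scatter of the measurement, so the two cannot be ordered. The furthest is compound 3, whose value lies higher by an amount beyond the scatter. Within the data shown here, no pair among the measured compounds differs in just one place, so no single structural step has yet been tied to a change in the read-out.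

The next compound, compound 4 `CC(C)c1ccc(Nc2ccc3c(c2)C(=O)N(C2CCC(=O)NC2=O)C3=O)cc1`, differs from compound 1 in one place: isopropyl in place of pentyl on an aromatic carbon. The change sits on the aromatic carbon para to a large group, where pentyl is exchanged for isopropyl. Among the measured compounds shown here, with no comparable step measured, the size of the effect is open. Given that compound 1 sits at a modest level in this assay with 12%, the step from compound 1 to compound 4 is expected to be small, a number 2 percentage points lower from compound 1 to compound 4 (within the scatter), and not beyond the scatter in either direction. Compound 4 is therefore estimated at 10%, with a range from 0% to 22%.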

Compound 4, a percentage reported as inhibition, at one concentration (the size of the read-out at that concentration, not a potency): 11%
Estimate against measurement, compound 4: 1 percentage points below; low and high end bracket the measured number.
By their numbers in this assay, from the lowest: compounds 2, 4 and 1 (each within the scatter of the next); then compound 3.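

Among these compounds, the exchange of pentyl for isopropyl is the first single change on the shared core that can be read in this assay, and a number 1 percentage points lower from compound 1 to compound 4 (within the scatter) shows that the read-out does not separate these two chains on this aromatic carbon, para to a large group. Going from the 5 heavy atoms of pentyl to the 3 of isopropyl, both without a ring, a hydrogen-bond donor or acceptor, or a net charge, therefore leaves compound 1 and compound 4 unordered, and this one step gives no sign that the length or branching of the chain matters here at the concentration tested. No measured information bears on why the number holds across this change.

Going by these compounds, whether an amine, a carboxylic acid or a longer chain such as octyl in place of pentyl at this position would move the number beyond the scatter remains open. Also open, on these data alone, is whether the same exchange of pentyl for isopropyl on compound 3 , which gives 23%, would likewise stay within the scatter.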